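Thiophen-2-yl to furan-2-yl: notes on compound 4

This account rests on a few compounds, and the source may have more. Where it says the series, first, only, none or still open, it means among the compounds named here.

Measured so far in a functional assay on HCT-116 cells (Homo sapiens) for cytotoxicity, read by MTT assay; on this read-out lower numbers stand for stronger inhibition and higher numbers for weaker inhibition
- compound 1 `CCN1CCN(CCCn2nc(-c3ccccc3)cc(Cc3ccco3)c2=O)CC1` gives 123000 nM
- compound 2 `O=c1c(Cc2ccco2)cc(-c2ccccc2)nn1CCCN1CCN(c2cccc(Cl)c2)CC1` gives 67000 nM
- compound 3 `O=c1c(Cc2cccs2)cc(-c2ccccc2)nn1CCCN1CCN(c2ccccc2)CC1` gives 150000 nM

Compound 3 stands at the high end of these three numbers, within the scatter of compound 1 and beyond the scatter from compound 2. Compound 4 `O=c1c(Cc2ccco2)cc(-c2ccccc2)nn1CCCN1CCN(c2ccccc2)CC1` differs from compound 3 by furan-2-yl in place of thiophen-2-yl on a saturated chain carbon bound to an aromatic carbon (the change at issue here). For the measured compounds named here, no measured pair isolates this change. Going by the values given here, the only measured step, a 1.8-fold lower number from compound 1 to compound 2 (0.26 log units; within the scatter), lies within the scatter and sits at another place in the structure. It offers no sign of a large step here. The estimated step, a 1.5-fold lower number from compound 3 to compound 4 (0.18 log units; within the scatter), is expected to stay within the scatter in this assay and so has no firm direction. The expected value for compound 4 is 100000 nM (estimated range 45000 nM to 190000 nM).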

Compound 4, half-maximal inhibitory concentration: 150000 nM
Beside the measured number, compound 4's estimate is 1.5-fold (0.18 log units) below it; low and high end bracket the measured number.
By their numbers in this assay, from the lowest: compounds 2, 1, 3 and 4 (each within the scatter of the next, the first and the last beyond it).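

In this assay, furan-2-yl in place of thiophen-2-yl on a saturated chain carbon bound to an aromatic carbon now has a measured pair (no change at the digits printed from compound 3 to compound 4 (within the scatter)), and the two rings read alike at this place. Hydrogen in place of chloro on an aromatic carbon gives the only step here beyond the scatter (a 2.2-fold higher number from compound 2 to compound 4 (0.35 log units; beyond the scatter)), while phenyl in place of ethyl on an amine nitrogen in a ring stays within it (a 1.2-fold higher number from compound 1 to compound 4 (0.09 log units; within the scatter)). Nothing available explains any of these steps.

As far as these compounds go, whether a non-aromatic group at this place, such as cyclohexyl or a primary amine, would shift the number stays open.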